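Trifluoromethyl for Methyl on the Anilide Ring

This account rests on a few compounds, and the source may have more. Where it says the series, first, only, none or still open, it means among the compounds named here.

In a functional assay on the whole organism for inhibition, with Rattus norvegicus as the target, read by paw edema, with stated times of 30 min and 3 h, at a dose of 0.28 mmol/kg by the oral route (a higher number here means more inhibition at the dose given (going by the name of the read-out), a lower number less inhibition), compound 1 `CNC(=O)c1nc(-c2cc(OC)c(OC)c(OC)c2)n(-c2ccc(OC)cc2)n1` gives 109%. Compound 2 `COc1ccc(-n2nc(C(=O)Nc3ccc(C)cc3)nc2-c2cc(OC)c(OC)c(OC)c2)cc1` gives 88% in this assay, the lower of the two numbers, reached by a number 21 percentage points lower from compound 1 to compound 2 (beyond the scatter). Compound 3 `COc1ccc(-n2nc(C(=O)Nc3ccc(C(F)(F)F)cc3)nc2-c2cc(OC)c(OC)c(OC)c2)cc1` differs from compound 2 only by trifluoromethyl in place of methyl on an aromatic carbon. For the measured compounds named here, no measured step concerns a change on that ring, so the one step available, from compound 1 to compound 2, is of a different kind and gives no direction. Compound 3 is therefore expected to change by a number 3 percentage points lower from compound 2 to compound 3 (within the scatter), within the scatter. Compound 3 is estimated at 85%, between 65% and 105%.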

Compound 3, a percentage reported as inhibition, in the whole organism at one dose (the size of the read-out at that dose, not a potency): 96%
For compound 3 the middle estimate is 11 percentage points below the measured one; measured number inside the range.
By their numbers in this assay, from the lowest: compounds 2 and 3 (each within the scatter of the next); then compound 1.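

In this assay the change to 4-(trifluoromethyl)phenyl from 4-methylphenyl gives a number 8 percentage points higher from compound 2 to compound 3 (within the scatter) and so this position accepts trifluoromethyl as well as methyl, with no difference that can be told from the scatter. The second aryl amide also stands apart from the methyl amide, with a number 13 percentage points lower from compound 1 to compound 3 (beyond the scatter) in the same assay, so the drop seen with 4-methylphenyl on the amide nitrogen recurs with 4-(trifluoromethyl)phenyl. Nothing available explains these numbers.

The compounds shown leave open how a carboxylic acid or an amine on this ring would read. They also leave open whether a longer chain such as ethyl on the amide nitrogen would stay with compound 1 or fall toward the aryl amides.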